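Methoxy Added to Compound 3: What to Expect

The compounds below may be only part of what the source reports. "The series", "measured", "known", "first", "only" and "open" are said of these compounds alone.

Compound 1 `C=C(C)[C@@H]1CC=C(Cn2cc(COc3cccc(C4NC(=O)NC(C)=C4C(=O)OCC)c3)nn2)CC1` and two close relatives were tested in a functional assay on HT-29 cells (Homo sapiens) for inhibition, read by sulforhodamine B assay, with a stated time of 48 h; on this read-out higher numbers stand for weaker inhibition of growth and lower numbers for stronger inhibition of growth. Compound 1 gives 73400 nM. Compound 2 `C=C(C)[C@@H]1CC=C(Cn2cc(COc3cc(C4NC(=O)NC(C)=C4C(=O)OCC)ccc3OC)nn2)CC1` carries a methoxy in place of a hydrogen on an aromatic carbon; in this assay compound 2 reaches > 100000 nM, which is a limit of the assay rather than a number. Compound 3 `C=C(C)[C@@H]1CC=C(Cn2cc(COc3cccc(C4NC(=O)NC(C)=C4C(C)=O)c3)nn2)CC1` has a methyl in place of the ethoxy on a carbonyl carbon, and in this assay compound 3 gives 86200 nM. Of the two plain numbers, compound 3 carries the higher, yet the step of a 1.2-fold higher number from compound 1 to compound 3 (0.07 log units; within the scatter) lies within the scatter, so no order between the two can be claimed. The third value is a limit: the limit of > 100000 nM in this assay, at which 1 of the 3 values shown sits.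

Compound 4 `C=C(C)[C@@H]1CC=C(Cn2cc(COc3cc(C4NC(=O)NC(C)=C4C(C)=O)ccc3OC)nn2)CC1` differs from compound 3 by methoxy in place of hydrogen on an aromatic carbon. The same change was made once before, with an at least 1.3-fold higher number from compound 1 to compound 2 (0.13 log units; that floor lies within the scatter). The floor of that step lies within the scatter, and compound 2 sits at a limit, so the true size of the step is not known. Compound 4 is therefore expected to show only a modest rise, a 1.3-fold higher number from compound 3 to compound 4 (0.13 log units; within the scatter), with a real chance that the assay again reports a limit. Compound 4 is estimated at 115000 nM, with a range from 70000 nM to 200000 nM.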

Compound 4, concentration for total growth inhibition: 96000 nM
The estimate for compound 4 lay 1.2-fold (0.08 log units) above the measured number; low and high end bracket the measured number.
By their numbers in this assay, from the lowest: compounds 1, 3 and 4 (each within the scatter of the next). At a limit, above all of these: compound 2.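

In this assay, methoxy in place of hydrogen on an aromatic carbon, ortho to a large group and para to a large group, now has a step that ends in a plain number rather than a limit: a 1.1-fold higher number from compound 3 to compound 4 (0.05 log units; within the scatter). On the core of compound 3, then, the numbers with hydrogen and with methoxy at this position cannot be told apart, which the earlier pair could not show. Read the other way, methyl in place of ethoxy on a carbonyl carbon, with the methoxy present, gives an at least 1.0-fold lower number from compound 2 to compound 4 (0.01 log units; that floor lies within the scatter), a step that starts from a limit and so says little about its true size.

From the compounds shown here alone, whether methoxy has the same effect on both cores remains unsettled: the same change on two cores in this assay, an at least 1.3-fold higher number (0.13 log units; that floor lies within the scatter) from compound 1 to compound 2 and a 1.1-fold higher number (0.05 log units; within the scatter) from compound 3 to compound 4; the limit leaves it open whether they differ What a hydroxyl, a chlorine or an amine at this same position would do is also open, including whether any of them would move the number beyond the scatter.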